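A few compounds are considered here, and "the series" means these few. Any claim that something is new, unique, unknown or untested is made for them only; others in the source may bear on it.

Measured compounds:
compound 1 `O=C(O)COc1ccncc1-c1ccc2ccccc2c1`, 16%
compound 2 `CN1CCN(C(=O)/C=C/c2ccncc2-c2ccc(F)cc2)CC1`, 84%
compound 3 `O=C(/C=C/c1ccncc1-c1ccc2cc[nH]c2c1)N1CCOCC1`, 102%

These three were tested in an assay on a protein complex for inhibition of CDK8/Cyclin C (Homo sapiens), with a stated time of 1 h, tested at 10 uM; on this read-out higher numbers stand for more inhibition at the one concentration tested (going by the name of the read-out) and lower numbers for less inhibition. Compound 1 gives the lowest number of the three, 16%. Compound 2, whose value of 84% lies nearest to it, is well beyond the usual scatter above it, and compound 3, at 102%, lies furthest from compound 1. Both of those higher compounds carry a three-carbon amide-bearing chain on the shared core where compound 1 carries its acid-bearing chain.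

Compound 4 `CN(C)C(=O)/C=C/c1ccncc1-c1ccc2ccccc2c1` has not yet been measured. It differs from compound 1 in one place: 2-(dimethylcarbamoyl)ethenyl in place of carboxymethoxy on an aromatic carbon. Because compound 2 reaches 84% with a similar chain, a large rise is expected, of about a number 64 percentage points higher from compound 1 to compound 4 (beyond the scatter) in this assay. Compound 4 is therefore estimated at 80%, within a range of 50% to 100%.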

Compound 4, a percentage reported as inhibition, at one concentration (the size of the read-out at that concentration, not a potency): 100%
The estimate for compound 4 lay 20 percentage points below the measured number; measured number inside the range.
By their numbers in this assay, from the lowest: compound 1; then compound 2; then compounds 4 and 3 (each within the scatter of the next).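

In this assay, replacing carboxymethoxy with 2-(dimethylcarbamoyl)ethenyl on the aromatic carbon opposite the ring nitrogen gives a number 84 percentage points higher from compound 1 to compound 4 (beyond the scatter). Within the data shown here, with the rest of the core unchanged, this is the first comparison here that ties a large difference to this one position. No measurement shown gives a reason for the rise. The whole chain changes in this step, so its separate parts cannot be told apart. From the compounds shown here alone, it remains open whether 2-carboxyethenyl, which keeps the carboxylic acid on the new chain, or the saturated 2-(dimethylcarbamoyl)ethyl chain would match compound 4.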